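Benzyl for Ethyl in the Ester: Cytotoxicity Stays Out of Range

The compounds below may be only part of what the source reports. "The series", "measured", "known", "first", "only" and "open" are said of these compounds alone.

Three compounds have been measured in an ADME assay on HEK293 cells (Homo sapiens) for cytotoxicity, with a stated time of 72 h; a higher number here means that more compound is needed for the effect, a lower number that less compound is needed:
Compound 1, `C=C[C@@](C)(/C=C/c1ccc(O)cc1)CC/C=C/C(=O)OCC`, gives > 36600 nM, which is a limit of this assay and not a number.
Compound 2, `C=C[C@@](C)(/C=C/c1ccc(O)cc1)CC/C=C/C(=O)OCc1ccccc1`, gives > 36600 nM, again a limit and not a number.
Compound 3, `C=C[C@@](C)(/C=C/c1ccc(O)c(/C=C/C(=O)OCC)c1)CCC=C(C)C`, gives > 36600 nM, also a limit and not a number.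

Compound 2 differs from compound 1 by phenyl in place of methyl on a saturated chain carbon bound to an oxygen next to a carbonyl group. The step this change made in this assay is a step that the two limits leave unreadable from compound 1 to compound 2, since both ends of the pair sit at the same limit. What ties the three measured values together is the limit of > 36600 nM in this assay, at which 3 of the 3 values shown sit, so none of the three compounds shows a cytotoxic effect within the range that this assay can read.

Compound 4, `C=C[C@@](C)(/C=C/c1ccc(O)c(/C=C/C(=O)OCc2ccccc2)c1)CCC=C(C)C`, is not yet measured. It differs from compound 3 by phenyl in place of methyl on a saturated chain carbon bound to an oxygen next to a carbonyl group, the same change at the same place as from compound 1 to compound 2. How the core of compound 3 differs from the core of compound 1 is not broken down here.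

The expectation for compound 4 rests on the limit of > 36600 nM in this assay, at which 3 of the 3 values shown sit, and on the fact that the same change left compound 1 and compound 2 both at the limit. Compound 4 is therefore expected to give about 40000 nM, most likely reported once more as a limit, with an estimated range from 20000 nM to 100000 nM. The step this estimate means, a step that the limit leaves unreadable from compound 3 to compound 4, is expected to be essentially nil.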

Compound 4, half-maximal effective concentration: > 36600 nM
Compound 4 gave a limit, no number (the forecaster's own chance of this, stated with the estimate: 80%); the middle value is on the limit's open side.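

In this assay compound 4 gives > 36600 nM, which is a limit and not a number. Compound 3 sits at the same limit, so no step can be read between compound 3 and compound 4: the limit of > 36600 nM in this assay, at which 4 of the 4 values shown sit.

The compounds shown leave open whether benzyl in place of ethyl changes cytotoxicity at all, and at what concentration any of the four would show an effect.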